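Swapping the piperidine substituent on a hydantoin-spiro amide

A few compounds are considered here, and "the series" means these few. Any claim that something is new, unique, unknown or untested is made for them only; others in the source may bear on it.

Compound 1 `CCC1CCCN(C(=O)CN2CN(c3ccccc3)C3(CCN(C(=O)c4ccc(C(C)(C)C)cc4)CC3)C2=O)C1` is one of two measured members of this small set. In an assay on HEK293 cells for displacement of a labelled ligand from NPC1-like intracellular cholesterol transporter 1 (Homo sapiens) (a higher number here means a weaker inhibitor, a lower number a stronger inhibitor), compound 1 gives 3900 nM, the lowest of the two numbers, though the margin to its neighbour is slight. Compound 2 `CC(C)(C)OC(=O)NC1CCCN(C(=O)CN2CN(c3ccccc3)C3(CCN(C(=O)c4ccc(C(C)(C)C)cc4)CC3)C2=O)C1`, which carries (tert-butoxycarbonyl)amino in place of ethyl on a saturated ring carbon, gives 4200 nM in this assay; the step of a 1.1-fold higher number from compound 1 to compound 2 (0.03 log units; within the scatter) lies within the scatter. Compound 3 `CC(C)(C)c1ccc(C(=O)N2CCC3(CC2)C(=O)N(CC(=O)N2CCCCC2CO)CN3c2ccccc2)cc1` has not yet been measured. It differs from compound 1 as follows: 2-(hydroxymethyl)piperidin-1-yl in place of 3-ethylpiperidin-1-yl on a carbonyl carbon. Among the measured compounds shown here, the only step that bears on this region is the one from compound 1 to compound 2, and it was flat, so a further exchange of the group on the piperidine is expected to move the number little, with an estimated step of a 1.0-fold higher number from compound 1 to compound 3 (0.01 log units; within the scatter). Compound 3 is therefore estimated at 4000 nM, within a range of 1500 nM to 11000 nM.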

Compound 3, half-maximal inhibitory concentration: 11800 nM
Beside the measured number, compound 3's estimate is 3.0-fold (0.47 log units) below it; measured number above the stated range.
By their numbers in this assay, from the lowest: compounds 1 and 2 (each within the scatter of the next); then compound 3.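

The group on this carbonyl carbon is not as indifferent as the first step suggested, since in this assay replacing 3-ethylpiperidin-1-yl with 2-(hydroxymethyl)piperidin-1-yl gives a 3.0-fold higher number from compound 1 to compound 3 (0.48 log units; beyond the scatter) and so a step beyond the scatter. The piperidine ring and the heavy-atom count stay the same in this exchange, so a step of this modest size can arise without any change in either; what does change is that one oxygen replaces one carbon, a hydrogen-bond donor and an acceptor enter, and the substituent's place on the ring differs. Nothing shown here explains why the number rises.

The compounds shown leave open whether the hydroxymethyl group or its place on the ring accounts for the step. A 3-(hydroxymethyl)piperidin-1-yl or a 2-ethylpiperidin-1-yl group on the same carbonyl carbon would separate these two changes.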